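The source may hold more compounds than are shown below. What is called first, only, known or untested is meant among the compounds shown, and "the series" means these compounds.

Measured so far:
- compound 1 `O=C(Nc1cccnc1)c1ccccc1OCc1ccccc1F` gives 3500 nM
- compound 2 `O=C(Nc1cccnc1)c1ccccc1OCc1cc(Cl)ccc1Cl` gives 990 nM
- compound 3 `Cc1ccc(F)cc1COc1ccccc1C(=O)Nc1cccnc1` gives 740 nM

All three numbers come from an assay on lysate for inhibition of phosphatidylcholine:ceramide cholinephosphotransferase 2 (Homo sapiens), read by HPLC, with stated times of 30 min and 2 h; a higher number here means a weaker inhibitor, a lower number a stronger inhibitor. Compound 1 stands highest of the three; the nearest step down from it is a 3.5-fold lower number from compound 1 to compound 2 (0.55 log units; beyond the scatter) and the furthest is a 4.7-fold lower number from compound 1 to compound 3 (0.67 log units; beyond the scatter). Between the two lower compounds the step of a 1.3-fold lower number from compound 2 to compound 3 (0.13 log units; within the scatter) is within the scatter, so compound 2 and compound 3 cannot be ordered against each other.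

Compound 4 `Cc1ccc(Cl)cc1COc1ccccc1C(=O)Nc1cccnc1` is the next member. It differs from compound 1 as follows: 5-chloro-2-methylphenyl in place of 2-fluorophenyl on a saturated chain carbon bound to an oxygen on an aromatic ring

Both measured steps away from compound 1 bear on this change, since each swaps the same group at the same place: a 3.5-fold lower number from compound 1 to compound 2 (0.55 log units; beyond the scatter) and a 4.7-fold lower number from compound 1 to compound 3 (0.67 log units; beyond the scatter), each a modest lowering beyond the scatter. The entering group of compound 4 shares the 2-methyl pattern with compound 3 and the chlorine with compound 2. A modest lowering of similar size is therefore expected, a 5.0-fold lower number from compound 1 to compound 4 (0.70 log units; beyond the scatter). In this assay compound 4 is estimated at 700 nM, with the likely range from 300 nM to 1800 nM.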

Compound 4, half-maximal inhibitory concentration: 1100 nM
Compound 4: middle estimate off by 1.6-fold (0.20 log units), on the low side; the range from low to high includes it.
By their numbers in this assay, from the lowest: compounds 3, 2 and 4 (each within the scatter of the next); then compound 1.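

In this assay, a third entering group at this place, 5-chloro-2-methylphenyl in place of 2-fluorophenyl, also gives a modest lowering (a 3.2-fold lower number from compound 1 to compound 4 (0.50 log units; beyond the scatter)). Single exchanges on the aromatic ring among the lower compounds do not separate them: chloro in place of fluoro (a 1.5-fold higher number from compound 3 to compound 4 (0.17 log units; within the scatter)) and methyl in place of chloro (a 1.1-fold higher number from compound 2 to compound 4 (0.05 log units; within the scatter)) both lie within the scatter, so compounds 2, 3 and 4 cannot be ordered against each other. No measured evidence bears on these results.

The compounds shown leave open how this place responds to a methoxy group, a trifluoromethyl group or an amine on the aromatic ring, or to a longer chain in place of the saturated chain carbon. Going by these compounds alone, they also vary only this one group, so the effect of changes elsewhere on the core of compound 1 remains open.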